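Ring Replacement on the Shared Core and Buffer Half-Life

The source may hold more compounds than are shown below. What is called first, only, known or untested is meant among the compounds shown, and "the series" means these compounds.

Compound 1 `CC(C)(O/N=C(\C(=O)N[C@@H]1C(=O)N(S(=O)(=O)O)[C@@H]1CN1CCC1=O)c1csc(N)n1)C(=O)O`, in a physicochemical assay for metabolic stability, read by HPLC and mass spectrometry, in phosphate buffer, at 37 degrees C, at pH 7.4; on this read-out lower numbers stand for a shorter-lived compound and higher numbers for a longer-lived compound: > 1000 h, a limit of the assay.
Compound 2 `CC(C)(O/N=C(\C(=O)N[C@@H]1C(=O)N(S(=O)(=O)O)[C@@H]1CN1C[C@@H](CN)OC1=O)c1csc(N)n1)C(=O)O`, in this assay: > 37 h, a limit of the assay.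
Compound 3 `CC(C)(O/N=C(\C(=O)N[C@@H]1C(=O)N(S(=O)(=O)O)[C@@H]1Cn1cc(CO)nn1)c1csc(N)n1)C(=O)O`, in this assay: > 37 h, a limit of the assay.

Compound 1 stands only at a limit (the limit of > 1000 h in this assay, at which 1 of the 3 values shown sits), while the two others sit at a lower limit (the limit of > 37 h in this assay, at which 2 of the 3 values shown sit). Compound 4 `CC(C)(O/N=C(\C(=O)N[C@@H]1C(=O)N(S(=O)(=O)O)[C@@H]1Cn1ncnc1CN)c1csc(N)n1)C(=O)O` differs from compound 1 by a group of 7 heavy atoms (3 carbon, 4 nitrogen; one five-membered aromatic ring with 3 hetero atoms) in place of a group of 5 heavy atoms (3 carbon, 1 nitrogen, 1 oxygen; one four-membered non-aromatic ring with 1 hetero atom), on a saturated chain carbon bound to a saturated ring carbon. Going by the values given here, the steps that bear on this change, a step that the two limits leave unreadable from compound 1 to compound 2 and a step that the two limits leave unreadable from compound 1 to compound 3, are both unreadable, so no direction and no size can be taken from them. The step from compound 1 to compound 4 is therefore expected to be an at least 5.0-fold lower number from compound 1 to compound 4 (0.69 log units; beyond the scatter), with a wide range. Compound 4 is estimated at 200 h, between 37 h and 1000 h.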

Compound 4, half-life: > 37 h
Compound 4 ended at the assay's limit; the forecaster's own chance of this, stated with the estimate: 80%; the middle value is on the limit's open side.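

No step from compound 1, compound 2 or compound 3 to compound 4 can be read in this assay, as each of the four values is a limit of the assay: the limit of > 37 h in this assay, at which 3 of the 4 values shown sit.

The compounds shown leave open how long each one actually lasts, and whether any of these ring replacements changes the half-life at all.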